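A few compounds are considered here, and "the series" means these few. Any claim that something is new, unique, unknown or untested is made for them only; others in the source may bear on it.

Series notes. Compound 1 `Oc1cccc(-c2cc(-c3cccs3)cc(-c3ccccc3O)n2)c1` sits at a limit in a functional assay on HeLa cells (Homo sapiens) for cytotoxicity, read by CCK-8 assay; on this read-out lower numbers stand for stronger inhibition and higher numbers for weaker inhibition: compound 1 gives > 50000 nM, a limit of the assay rather than a number. Compound 3 `Oc1ccc(-c2cc(-c3cccs3)cc(-c3ccc(O)cc3)n2)cc1` likewise gives > 50000 nM, again a limit. Within the data shown here, compound 2 `Oc1ccc(-c2cc(-c3cccs3)cc(-c3cccc(O)c3)n2)cc1` gives 4140 nM in this assay and so holds the only number in the set. The other two values are limits (the limit of > 50000 nM in this assay, at which 2 of the 3 values shown sit). The measured steps are an at least 12-fold lower number from compound 1 to compound 2 (1.08 log units; beyond the scatter) and an at least 12-fold higher number from compound 2 to compound 3 (1.08 log units; beyond the scatter); both move hydroxyphenyl groups, not the five-membered ring. Compound 4 `Oc1ccc(-c2cc(-c3ccoc3)cc(-c3cccc(O)c3)n2)cc1` differs from compound 2 by furan-3-yl in place of thiophen-2-yl on an aromatic carbon. Among the measured compounds shown here, no measured step bears on this change. The expected step is therefore a 1.2-fold higher number from compound 2 to compound 4 (0.08 log units; within the scatter), none beyond the scatter. Compound 4 is estimated at 5000 nM in this assay, with a range of 1500 nM to 20000 nM.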

Compound 4, half-maximal inhibitory concentration: 3310 nM
Compound 4: middle estimate off by 1.5-fold (0.18 log units), on the high side; measured number inside the range.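

This position, opposite the ring nitrogen, now has its first measured step: in this assay the exchange gives a 1.3-fold lower number from compound 2 to compound 4 (0.10 log units; within the scatter). Unlike the earlier steps, which moved hydroxyphenyl groups, this one changes only the five-membered ring, and with the 3-hydroxyphenyl and 4-hydroxyphenyl groups held fixed the difference stays within the scatter. Nothing on hand gives a reason for this step.

On these data alone, whether an amine or a carboxylic acid at this position would stay within the scatter remains open. Also open, as far as these compounds go, is how furan-3-yl behaves with the hydroxyl placements of compound 1 and compound 3.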